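Ortho substitution on the benzoate of a piperidinyl ester series

The source may report more compounds than this note shows. Statements on the series, on what has been measured and on what is new or still open speak of the compounds shown alone.

Measured so far:
compound 1 `COc1ccccc1C(=O)OC1CCN(C)CC1`: 1.43
compound 2 `COc1cccc(OC)c1C(=O)OC1CCN(C)CC1`: 0.63
compound 3 `CN1CCC(OC(=O)c2ccc(C(C)(C)C)cc2)CC1`: 1.13

In a functional assay on the whole organism with Mus musculus as the target (a higher number here means a more potent compound, by a factor of ten per unit of this negative logarithm, a lower number a less potent compound), compound 1 gives 1.43, the highest of the three numbers; compound 3 sits within the scatter of it with 1.13, so no order between these two is claimed. Among the measured compounds shown here, the one counted step is a number 0.80 log units lower from compound 1 to compound 2 (beyond the scatter), a modest loss beyond the scatter.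

The next compound, compound 4 `CN1CCC(OC(=O)c2ccccc2Br)CC1`, differs from compound 1 as follows:
bromo in place of methoxy on an aromatic carbon

For the measured compounds named here, no measured step swaps one group for another at the same aromatic carbon; the step from compound 1 to compound 2 concerns a second methoxy at a different carbon and bears on this change only loosely. Going by the values given here, with a single substituent kept ortho to a large group, and no step showing the series to be sensitive there, a step near zero in this assay is expected, with some chance of a small loss. Compound 4 is therefore estimated at 1.3 (range 0.8 to 1.8), a step of a number 0.13 log units lower from compound 1 to compound 4 (within the scatter) that is expected to stay within the scatter.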

Compound 4, logarithm of the reciprocal of the active concentration, log(1/C): 1.21
Beside the measured number, compound 4's estimate is 0.09 log units above it; the range from low to high includes it.
By their numbers in this assay, from the lowest: compound 2; then compounds 3, 4 and 1 (each within the scatter of the next).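

In this assay, among the compounds shown here, bromo in place of methoxy gives a number 0.22 log units lower from compound 1 to compound 4 (within the scatter) and is the first reading of one group exchanged for another at this aromatic carbon. With a single substituent ortho to a large group, the series therefore accepts either methoxy or bromo without a change beyond the scatter, even though the hydrogen-bond acceptor counted on methoxy is absent from bromo. No measurement available here explains this result.

Going by these compounds, whether an amine, a carboxylic acid or a longer alkoxy chain at this aromatic carbon would keep the number within the scatter of compound 1 remains open. On these data alone, it is also open whether bromo would tolerate a second substituent on the ring, the change that separates compound 2 from compound 1 with methoxy as the added group.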